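Acylguanidine series: ether in place of thioether

The source may hold more compounds than are shown below. What is called first, only, known or untested is meant among the compounds shown, and "the series" means these compounds.

Measured compounds:
compound 1 `CCCc1cc(C)c(C(=O)N=C(N)N)cc1S(C)(=O)=O`, 5.7 nM in a functional assay for inhibition of sodium/hydrogen exchanger (Oryctolagus cuniculus); on this read-out lower numbers stand for stronger inhibition and higher numbers for weaker inhibition
compound 2 `CSc1cc(C)c(C(=O)N=C(N)N)cc1S(C)(=O)=O`, 6 nM
compound 3 `Cc1cc(SC(C)(C)C)c(S(C)(=O)=O)cc1C(=O)N=C(N)N`, 22 nM

Compound 3 stands highest of the three numbers in this assay. Its nearest neighbour is compound 2, reached by a 3.7-fold higher number from compound 2 to compound 3 (0.56 log units; beyond the scatter); the step of a 3.9-fold higher number from compound 1 to compound 3 (0.59 log units; beyond the scatter) is of the same size. Compound 1 and compound 2 sit within the scatter of each other, as a 1.1-fold higher number from compound 1 to compound 2 (0.02 log units; within the scatter) shows.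

Compound 4 `Cc1cc(OC2CCCC2)c(S(C)(=O)=O)cc1C(=O)N=C(N)N` is the next compound. Relative to compound 3 the change is cyclopentyloxy in place of (tert-butyl)sulfanyl on an aromatic carbon.

Among the compounds with values here, two measured steps bear on this change, both ending at compound 3: a 3.9-fold higher number from compound 1 to compound 3 (0.59 log units; beyond the scatter) and a 3.7-fold higher number from compound 2 to compound 3 (0.56 log units; beyond the scatter). Both show that the (tert-butyl)sulfanyl group carries a modest cost against the smaller propyl and methylsulfanyl groups. Within the data shown here, no measured step exchanges a sulfur-linked group for an oxygen-linked one, and no measured compound carries a ring at this position, so the direction of the step to compound 4 is not fixed by the data. Cyclopentyloxy is comparable in size to (tert-butyl)sulfanyl, so the expected step of a 1.5-fold lower number from compound 3 to compound 4 (0.17 log units; within the scatter) lies within the scatter. For compound 4 in this assay the estimate is 15 nM, with a range from 5 nM to 45 nM.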

Compound 4, half-maximal inhibitory concentration: 27 nM
Estimate against measurement, compound 4: 1.8-fold (0.26 log units) below, and the stated range covers the measured number.
By their numbers in this assay, from the lowest: compounds 1 and 2 (each within the scatter of the next); then compounds 3 and 4 (each within the scatter of the next).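

In this assay, the step of a 1.2-fold higher number from compound 3 to compound 4 (0.09 log units; within the scatter) shows that cyclopentyloxy and (tert-butyl)sulfanyl cannot be told apart at this position, so a sulfur link is not needed here to hold the number of compound 3, and a five-membered non-aromatic ring of carbon only is accepted. The gap to the low pair remains with the new group, as the steps of a 4.5-fold higher number from compound 2 to compound 4 (0.65 log units; beyond the scatter) and a 4.7-fold higher number from compound 1 to compound 4 (0.68 log units; beyond the scatter) are both modest and beyond the scatter, so the cost seen with (tert-butyl)sulfanyl is not confined to that group. No measured evidence bears on the reason for this result.

The linking atom itself stays unresolved, since the two groups differ in both link and carbon part; the comparisons of methoxy with methylsulfanyl and of cyclopentylsulfanyl with cyclopentyloxy would separate these two changes. Also open, from the compounds shown here alone, is how an amine such as dimethylamino, or a longer chain such as pentyl, would behave at this position on the shared core.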